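Methoxy Leaves, Nitro Enters: A Cytotoxicity Estimate

A few compounds are considered here, and "the series" means these few. Any claim that something is new, unique, unknown or untested is made for them only; others in the source may bear on it.

Measured so far:
Compound 1, `N#CC1=C(N)N(c2ccc(S(N)(=O)=O)cc2)C2=C(CCCC2)C1c1ccccc1`: in a functional assay on Ehrlich cells (Mus musculus) for cytotoxicity, read by trypan blue exclusion, with a stated time of 2 h, tested at 50 ug/mL (a higher number here means a stronger effect of the compound at the concentration tested, a lower number a weaker effect), compound 1 gives 20%.
Compound 2, `COc1ccc(C2C(C#N)=C(N)N(c3ccc(S(N)(=O)=O)cc3)C3=C2CCCC3)cc1`: in this assay compound 2 gives 100%.

For the measured compounds named here, compound 2 stands at the top of these two numbers, with compound 1 as its only neighbour. Going by the values given here, the single measured step, a number 80 percentage points higher from compound 1 to compound 2 (beyond the scatter), came from a methoxy in place of hydrogen on an aromatic carbon, a change well beyond the scatter.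

Compound 3, `N#CC1=C(N)N(c2ccc(S(N)(=O)=O)cc2)C2=C(CCCC2)C1c1cccc([N+](=O)[O-])c1`, differs from compound 2 in one place: 3-nitrophenyl in place of 4-methoxyphenyl on a saturated ring carbon. Among the compounds with values here, the measured step bears on this directly, since the methoxy whose arrival gave the large rise from compound 1 to compound 2 now departs; the nitro group that enters has no measured counterpart, so its own contribution is unknown. A drop in this assay is therefore expected, though of uncertain size. The range given is wide. The estimated step for compound 3 is a number 55 percentage points lower from compound 2 to compound 3 (beyond the scatter). Compound 3 is expected to give 45%, with a likely range from 10% to 90%.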

Compound 3, a percentage reported as activity, at one concentration (the size of the read-out at that concentration, not a potency): 2%
Estimate against measurement, compound 3: 43 percentage points above; measured number below the stated range.
By their numbers in this assay, from the lowest: compound 3; then compound 1; then compound 2.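

In this assay, the group on this saturated ring carbon proves able to carry the read-out from one end of the measured values to the other: 3-nitrophenyl in place of 4-methoxyphenyl gives a number 98 percentage points lower from compound 2 to compound 3 (beyond the scatter). The nitro group also has a measured effect of its own, with a number 18 percentage points lower from compound 1 to compound 3 (beyond the scatter), so on the phenyl ring it goes with a modest fall where methoxy went with a large rise. Compound 3 is thus the weakest of the three at the concentration tested, but nothing available here says why these two groups part ways.

Methoxy and nitro differ both in the group itself and in where it sits on the phenyl ring, so these compounds cannot separate the two. As far as these compounds go, how a chlorine or an amine on that ring would behave also stays open.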